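This account rests on a few compounds, and the source may have more. Where it says the series, first, only, none or still open, it means among the compounds named here.

In an ADME assay on MT4 cells (Homo sapiens) for cytotoxicity, read by MTT assay, with a stated time of 5 days (a lower number here means that less compound is tolerated, a higher number that more compound is tolerated), compound 1 `COc1cc2nc([S+]([O-])CC(=O)Nc3cccc(C(F)(F)F)c3)nc(Nc3c(Cl)cc(/C=C/C#N)cc3Cl)c2cc1OC` gives 21800 nM and compound 2 `COc1cc2nc([S+]([O-])CC(=O)Nc3ccc(C(F)(F)F)cc3)nc(Nc3c(Cl)cc(/C=C/C#N)cc3Cl)c2cc1OC` gives 22000 nM. These two differ by a 1.0-fold higher number from compound 1 to compound 2 (0.00 log units; within the scatter). Compound 3 `COc1cc2nc([S+]([O-])CC(=O)Nc3cccc(C#N)c3)nc(Nc3c(Cl)cc(/C=C/C#N)cc3Cl)c2cc1OC` gives >= 70300 nM, which is a limit of the assay and not a number. Its place on the scale is therefore (the limit of >= 70300 nM in this assay, at which 1 of the 3 values shown sits). Its steps from the other two are an at least 3.2-fold higher number from compound 1 to compound 3 (0.50 log units; beyond the scatter) and an at least 3.1-fold higher number from compound 2 to compound 3 (0.50 log units; beyond the scatter), and both rest on that limit.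

The next change leads to compound 4 `COc1cc2nc([S+]([O-])CC(=O)Nc3ccc(S(N)(=O)=O)cc3)nc(Nc3c(Cl)cc(/C=C/C#N)cc3Cl)c2cc1OC`, with 4-sulfamoylphenyl in place of 3-cyanophenyl on an amide-type nitrogen. Going by the values given here, no measured step makes this exact exchange. The nearest is an at least 3.1-fold higher number from compound 2 to compound 3 (0.50 log units; beyond the scatter), which also replaces the group on that nitrogen, while a 1.0-fold higher number from compound 1 to compound 2 (0.00 log units; within the scatter) shows that the two trifluoromethyl compounds do not separate. Compound 4, like compound 3, carries no trifluoromethyl, so no step beyond the scatter is expected in this assay in either direction, although a modest fall remains possible. The expected step is an at least 1.1-fold lower number from compound 3 to compound 4 (0.06 log units; that floor lies within the scatter). The estimate for compound 4 is 60000 nM, with an expected range from 22000 nM to 120000 nM.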

Compound 4, half-maximal cytotoxic concentration: > 189000 nM
Compound 4: no number, only a limit; the forecaster's own chance of this, stated with the estimate: 40%; at least 3.1-fold (0.49 log units) between middle value and limit.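

In this assay compound 4 gives a limit and not a number: the limit of > 189000 nM in this assay, at which 1 of the 4 values shown sits.

With 4-sulfamoylphenyl on the amide-type nitrogen, the readable comparisons are an at least 8.5-fold higher number from compound 2 to compound 4 (0.93 log units; beyond the scatter) and an at least 8.6-fold higher number from compound 1 to compound 4 (0.93 log units; beyond the scatter), so a second group, after 3-cyanophenyl, now separates from the two trifluoromethyl compounds beyond the scatter. Across the four compounds, the two with trifluoromethyl give numbers and the two without it give limits, and none goes against this pattern; the step from compound 3 to compound 4 cannot be read, so the sulfamoyl and cyano groups cannot be placed in order.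

The compounds shown leave open how far the tolerated concentration actually rises for compound 3 and compound 4, since only limits stand for them. They also leave open whether other groups on that ring, such as a carboxylic acid, an amine or a methyl sulfone, would likewise separate from the trifluoromethyl compounds, and whether 4-cyanophenyl would match 3-cyanophenyl.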